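This account rests on a few compounds, and the source may have more. Where it says the series, first, only, none or still open, it means among the compounds named here.

The two measured compounds share a single core. Compound 1 `Cc1c(C(=O)N/N=C\c2cccc(F)c2)oc2cccc(O)c12` carries a 3-fluorophenyl group on the carbon with a double bond to nitrogen. In a functional assay on PC-3 cells (Homo sapiens) for inhibition (on this read-out higher numbers stand for weaker inhibition and lower numbers for stronger inhibition), compound 1 gives only a limit of the assay, >= 40000 nM. Compound 2 `Cc1c(C(=O)N/N=C\c2cc(O)ccc2O)oc2cccc(O)c12` carries a 2,5-dihydroxyphenyl group in that place. In this assay compound 2 gives 95500 nM, the only number shown here. The step that the limit leaves unreadable from compound 1 to compound 2 cannot be read because of the limit of >= 40000 nM in this assay, at which 1 of the 2 values shown sits. Compound 3 `Cc1c(C(=O)N/N=C\c2cc([N+](=O)[O-])ccc2O)oc2cccc(O)c12` differs from compound 2 by nitro in place of hydroxy on an aromatic carbon. Within the data shown here, the sole measured step concerns a different exchange and is itself unreadable, so no measured step shows how this change moves the read-out in this assay. Compound 2 sits at very weak inhibition, and nothing in the data points to a shift beyond the scatter. Compound 3 is therefore expected to stay close to compound 2. The expected step is a 1.2-fold lower number from compound 2 to compound 3 (0.08 log units; within the scatter). The estimate for compound 3 in this assay is 80000 nM, with a range from 20000 nM to 300000 nM, and a real chance that only a limit is reported.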

Compound 3, half-maximal inhibitory concentration: 17100 nM
Compound 3: middle estimate off by 4.7-fold (0.67 log units), on the high side; the measured number lies below the stated range.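

In this assay, nitro in place of hydroxy on this aromatic carbon, para to a hydroxy group and meta to a large group, gives a 5.6-fold lower number from compound 2 to compound 3 (0.75 log units; beyond the scatter), the only readable step among the compounds shown. It shows that this position of the ring is not silent: one exchange here moves the read-out beyond the scatter towards stronger inhibition, even though the step remains modest and compound 3 still needs a high concentration in this assay. The earlier comparison could not show any such movement, and the step involving compound 1 still cannot be read because compound 1 has only a limit: the limit of >= 40000 nM in this assay, at which 1 of the 3 values shown sits.

The compounds shown leave open whether the gain comes from losing the hydroxy group or from the nitro group itself, as only these two groups appear at this position. On these data alone, an amine, a methoxy group or a carboxylic acid on the same carbon would help to separate those two readings, and the effect of the same exchange on other cores also remains unknown.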